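This account rests on a few compounds, and the source may have more. Where it says the series, first, only, none or still open, it means among the compounds named here.

Measured so far, in a functional assay for inhibition, with Homo sapiens as the target; on this read-out lower numbers stand for stronger inhibition and higher numbers for weaker inhibition:
compound 1 `COc1ccccc1Nc1nccc(-c2cccnc2)n1` gives 9800 nM;
compound 2 `COc1ccc(Nc2nccc(-c3cccnc3)n2)cc1` gives 1700 nM;
compound 3 `Oc1ccc(Nc2nccc(-c3cccnc3)n2)cc1` gives 5100 nM.

Compound 2 and compound 3 differ in one place: hydrogen in place of methyl on an oxygen on an aromatic ring. That change brought a 3.0-fold higher number from compound 2 to compound 3 (0.48 log units; beyond the scatter). Compound 1 has the same atoms as compound 2 joined differently; how the two cores differ is not broken down here. The gap between compound 1 and compound 3 lies within the scatter, while the gap between compound 1 and compound 2 lies beyond it. The unmeasured compound 4 `Oc1ccccc1Nc1nccc(-c2cccnc2)n1` arises from compound 1 by the same change: hydrogen in place of methyl on an oxygen on an aromatic ring. Resting on compound 1 at 9800 nM and on the earlier step, compound 4 is expected to show a 2.6-fold higher number from compound 1 to compound 4 (0.41 log units; beyond the scatter). Among the measured compounds shown here, with only one prior example the transfer is uncertain, so compound 4 is estimated at 25000 nM, likely between 8000 nM and 80000 nM.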

Compound 4, half-maximal inhibitory concentration: 23500 nM
Compound 4: middle estimate off by 1.1-fold (0.03 log units), on the high side, and the stated range covers the measured number.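

In this assay, going from methoxy to hydroxy on the core of compound 1 gave a 2.4-fold higher number from compound 1 to compound 4 (0.38 log units; beyond the scatter). Set beside the earlier step on the other core, the same change raised the number on both, by amounts that cannot be told apart: the same change on two cores in this assay, a 3.0-fold higher number (0.48 log units; beyond the scatter) from compound 2 to compound 3 and a 2.4-fold higher number (0.38 log units; beyond the scatter) from compound 1 to compound 4, 1.3-fold (0.10 log units) apart, within the scatter of two such steps. This shows that the change carried over between these two cores, but two cores make no rule for the whole series, and the numbers do not say why the change weakens inhibition.

The compounds shown leave open what an amine in place of the hydroxy would do on either core. They also leave open the effect of a longer chain, such as ethyl, in place of the methyl on the oxygen.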